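Methyl to trifluoromethyl, tested across two cores

The source may report more compounds than this note shows. Statements on the series, on what has been measured and on what is new or still open speak of the compounds shown alone.

Compound 1 `Cc1ccc(-c2cc(/C=N/c3ccccc3)on2)cc1` gives 32000 nM in a functional assay on A549 cells (Homo sapiens) for inhibition, read by MTT assay, with a stated time of 24 h; a lower number here means a stronger inhibitor, a higher number a weaker inhibitor. Compound 2 `FC(F)(F)c1ccc(-c2cc(/C=N/c3ccccc3)on2)cc1` gives 38900 nM in this assay. The step of a 1.2-fold higher number from compound 1 to compound 2 (0.08 log units; within the scatter) comes from trifluoromethyl in place of methyl on an aromatic carbon.

Compound 3 `CCc1cc2ccccc2nc1-c1cc(-c2ccc(C)cc2)no1` reaches only a limit, > 100000 nM, in this assay; this is the limit of > 100000 nM in this assay, at which 1 of the 3 values shown sits. The difference between the core of compound 3 and the core of compound 1 is not broken down here.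

Compound 4 `CCc1cc2ccccc2nc1-c1cc(-c2ccc(C(F)(F)F)cc2)no1` is not yet measured. It differs from compound 3 by trifluoromethyl in place of methyl on an aromatic carbon, the same change as between compound 1 and compound 2. The expected step is a step that the limit leaves unreadable from compound 3 to compound 4, resting on a 1.2-fold higher number from compound 1 to compound 2 (0.08 log units; within the scatter). Because compound 3 already sits at the limit of > 100000 nM in this assay, at which 1 of the 3 values shown sits, the result for compound 4 is expected to remain at or beyond that limit. Compound 4 is estimated at 150000 nM in this assay, most likely reported as a limit again.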

Compound 4, half-maximal inhibitory concentration: > 100000 nM
Compound 4 gave a limit, no number; the forecaster's own chance of this, stated with the estimate: 80%; the middle value does not contradict the limit.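

Compound 3 and compound 4 both give only a limit in this assay, so no step can be read between them: the limit of > 100000 nM in this assay, at which 2 of the 4 values shown sit.

From the compounds shown here alone, whether trifluoromethyl in place of methyl changes the result on the core of compound 3 stays open.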